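The compounds below may be only part of what the source reports. "The series", "measured", "known", "first", "only" and "open" are said of these compounds alone.

Of the compounds shown here, three have been tested so far, all sharing one core and differing only in the group carried on a nitrogen on an aromatic ring. Compound 1, `CC(C)CC(=O)Nc1ncc(-c2cccc(Cl)c2)c(-c2ccccc2)n1`, gives 56% in an assay on CHO cells for displacement of a labelled ligand from adenosine receptor A1 (Homo sapiens), read by scintillation counting, with a stated time of 1 h, tested at 1 uM; a higher number here means more inhibition at the concentration tested (going by the name of the read-out), a lower number less inhibition. Compound 2, `Clc1cccc(-c2cnc(Nc3ccccc3)nc2-c2ccccc2)c1`, gives 34%, and compound 3, `CC(C)Nc1ncc(-c2cccc(Cl)c2)c(-c2ccccc2)n1`, gives 71%. Compound 3 thus stands highest of the three, with a number 15 percentage points higher from compound 1 to compound 3 (beyond the scatter) and a number 37 percentage points higher from compound 2 to compound 3 (beyond the scatter), both changes sitting on the same nitrogen.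

Compound 4, `C#CCNc1ncc(-c2cccc(Cl)c2)c(-c2ccccc2)n1`, is the next variation at that nitrogen: propargyl in place of isopropyl on a nitrogen on an aromatic ring. All three measured steps bear on this position. The swap of a phenyl for an isobutylcarbonyl gave a number 22 percentage points lower from compound 1 to compound 2 (beyond the scatter), a modest change, while replacing the phenyl by an isopropyl gave a large rise. The move from isopropyl to propargyl is a smaller alteration than any of those, exchanging one short chain without a ring for another of the same length.

For compound 4 the expected result is therefore no step beyond the scatter, or at most a slight fall, giving an estimated a number 6 percentage points lower from compound 3 to compound 4 (within the scatter). The estimate for compound 4 is 65%, within a range from 45% to 85%.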

Compound 4, a percentage reported as inhibition, at one concentration (the size of the read-out at that concentration, not a potency): 76%
Beside the measured number, compound 4's estimate is 11 percentage points below it, within the range that was stated.
By their numbers in this assay, from the lowest: compound 2; then compound 1; then compounds 3 and 4 (each within the scatter of the next).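

In this assay, propargyl in place of isopropyl on the nitrogen gives a number 5 percentage points higher from compound 3 to compound 4 (within the scatter), so a chain with a triple bond outside aromatic rings and a branched chain of the same heavy-atom count read alike at this position. Propargyl also stands clear of the other two groups, with a number 42 percentage points higher from compound 2 to compound 4 (beyond the scatter) and a number 20 percentage points higher from compound 1 to compound 4 (beyond the scatter), so among these four compounds the two short chains without a ring, isopropyl and propargyl, form a pair apart from phenyl and isobutylcarbonyl, and none of the four goes against this grouping. Nothing available here explains why these groups give these numbers.

Still open, on these data alone, is how far this grouping extends: a longer chain such as n-butyl, a small ring such as cyclopropyl, or a chain ending in an amine or a carboxylic acid on this nitrogen could each fit the pair or break from it. As far as these compounds go, the read-out also comes from a single concentration, so it remains open whether compound 3 and compound 4 would still read alike if compared as full potencies.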